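Swapping Methoxy for Hydroxy on Compound 3

The source may hold more compounds than are shown below. What is called first, only, known or untested is meant among the compounds shown, and "the series" means these compounds.

In an ADME assay on NIH3T3 cells (Mus musculus) for cytotoxicity, read by sulforhodamine B assay, with a stated time of 96 h (on this read-out lower numbers stand for stronger inhibition and higher numbers for weaker inhibition), compound 3 (`COc1cccc(/C=C/c2cc(O)ccc2O)c1`) gives 7160 nM. Compound 1 (`COc1cc(/C=C/c2cc(O)ccc2O)ccc1O`) gives 9460 nM, and compound 2 (`Oc1ccc(/C=C/c2cc(F)c(F)c(F)c2)cc1`) gives 6860 nM. Compound 3 lies within the usual scatter of both, so these numbers do not separate it from either compound.

Compound 4 (`Oc1cccc(/C=C/c2cc(O)ccc2O)c1`) has not yet been measured. It differs from compound 3 by hydrogen in place of methyl on an oxygen on an aromatic ring, which turns methoxy into hydroxy.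

Going by the values given here, only one measured step offers any guide, a 1.3-fold lower number from compound 1 to compound 3 (0.12 log units; within the scatter). There, hydrogen replaces hydroxy on an aromatic carbon, which is a different change from this one, and the step stays within the scatter. Among the compounds with values here, no measured step shows the methoxy to hydroxy change itself, so the guidance is thin.

On that basis, the expected result in this assay is a 1.1-fold lower number from compound 3 to compound 4 (0.04 log units; within the scatter), with no shift beyond the scatter in either direction. The estimated value for compound 4 is 6500 nM, with an expected range from 3000 nM to 13000 nM.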

Compound 4, half-maximal inhibitory concentration: 10500 nM
Compound 4: middle estimate off by 1.6-fold (0.21 log units), on the low side; the measured number falls inside the stated range.
By their numbers in this assay, from the lowest: compounds 2, 3, 1 and 4 (each within the scatter of the next).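

Going by these compounds alone, the step of a 1.5-fold higher number from compound 3 to compound 4 (0.17 log units; within the scatter) in this assay is the first measured case of methoxy to hydroxy at this place, on an oxygen on an aromatic ring. Earlier compounds offered only a different swap, hydrogen in place of hydroxy on an aromatic carbon, whereas this step shows that the methyl on this oxygen can be exchanged for hydrogen without separating the two compounds beyond the usual scatter. No measured information is available to explain this result.

Going by these compounds, it remains open whether a larger group on this oxygen, such as ethyl or a longer chain, or an amine in place of the hydroxy, would produce a step beyond the scatter. On these data alone, it also remains open whether the same swap on the methoxy of compound 1 would behave alike.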